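Swapping dimethylamino for hydroxy on a shared core

The source may hold more compounds than are shown below. What is called first, only, known or untested is meant among the compounds shown, and "the series" means these compounds.

Of the compounds shown here, three with one shared core have been measured in a functional assay on KB cells (Homo sapiens) for inhibition, with a stated time of 72 h; on this read-out higher numbers stand for weaker inhibition and lower numbers for stronger inhibition. Compound 1 `COc1ccc(S(=O)(=O)N2CCc3cccc(-c4ccc(N)cc4)c32)cc1` gives 249 nM, compound 2 `COc1ccc(S(=O)(=O)N2CCc3cccc(-c4ccc(N(C)C)cc4)c32)cc1` gives 539 nM, and compound 3 `COc1ccc(S(=O)(=O)N2CCc3cccc(-c4c(F)c(F)c(F)c(F)c4F)c32)cc1` gives 4040 nM. Compound 2 therefore holds the second highest of these three numbers, nearer to compound 1 than to compound 3.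

The next compound, compound 4 `COc1ccc(S(=O)(=O)N2CCc3cccc(-c4ccc(O)cc4)c32)cc1`, has not yet been measured. It differs from compound 2 as follows: hydroxy in place of dimethylamino on an aromatic carbon. In words, hydroxy stands in place of dimethylamino on an aromatic carbon.

For the measured compounds named here, only one measured step involves this dimethylamino group: a 2.2-fold higher number from compound 1 to compound 2 (0.34 log units; beyond the scatter). That step is modest and replaces amino with dimethylamino. Hydroxy is not amino, so this step is only a rough guide, but removing dimethylamino may reverse it. The expected change is a 2.1-fold lower number from compound 2 to compound 4 (0.32 log units; beyond the scatter), a modest move towards stronger inhibition. For compound 4 the estimated value is 260 nM, with an expected range of 100 nM to 700 nM.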

Compound 4, half-maximal inhibitory concentration: 129 nM
Estimate against measurement, compound 4: 2.0-fold (0.30 log units) above; low and high end bracket the measured number.
By their numbers in this assay, from the lowest: compounds 4 and 1 (each within the scatter of the next); then compound 2; then compound 3.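

The change to hydroxy gives a 4.2-fold lower number from compound 2 to compound 4 (0.62 log units; beyond the scatter), so it shifts the number in the same direction as going from dimethylamino back to amino would. The other new step, a 1.9-fold lower number from compound 1 to compound 4 (0.29 log units; within the scatter), leaves hydroxy and amino indistinguishable in this assay, and among the three groups compared at this place on the ring, dimethylamino alone stands apart from the other two. The swap to hydroxy replaces three heavy atoms with one and adds a hydrogen-bond donor, but no supporting information shows which of these differences matters, or why.

Methylamino and methoxy would test the ground between these groups at the same place. A carboxylic acid would show whether a quite different group can match hydroxy and amino there.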